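The compounds below may be only part of what the source reports. "The series", "measured", "known", "first", "only" and "open" are said of these compounds alone.

Of the compounds shown here, two have numbers so far, and both share a core in which an acetate-bearing chain carries a double bond and a ketone. Compound 1 `CC(=O)OC/C(=C\C1CCCCC1)C(=O)c1ccccc1` carries a plain phenyl ketone, and in a functional assay on SW1573 cells (Homo sapiens) for inhibition, read by sulforhodamine B assay, with a stated time of 48 h (on this read-out higher numbers stand for weaker inhibition of growth and lower numbers for stronger inhibition of growth), compound 1 gives 19000 nM. Compound 2 `CC(=O)OC/C(=C\C1CCCCC1)C(=O)c1ccc(Cl)cc1` differs from it only by a chloro in place of hydrogen on an aromatic carbon, and in this assay compound 2 gives 18000 nM. That single step is a 1.1-fold lower number from compound 1 to compound 2 (0.02 log units; within the scatter), so the two values tell the same story. Compound 2 therefore stands on the lower of the two numbers, but its separation from compound 1 is within the scatter, so no order can be read from it.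

Compound 3 `CC(=O)OC/C(=C\c1ccc(Cl)cc1Cl)C(=O)c1ccc(Cl)cc1` is the next question. The change from compound 2 is 2,4-dichlorophenyl in place of cyclohexyl on a double-bonded chain carbon bound to a double-bonded chain carbon. Within the data shown here, no measured step touches this position; the only step on record, from compound 1 to compound 2, concerns the ketone side and was within the scatter. With nothing to anchor a direction, the expectation for compound 3 is a step of about a 1.2-fold lower number from compound 2 to compound 3 (0.08 log units; within the scatter) in this assay, held wide. The estimate for compound 3 is 15000 nM, with a range from 4000 nM to 50000 nM.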

Compound 3, concentration for 50% growth inhibition: 3400 nM
Compound 3: the middle estimate sits 4.4-fold (0.64 log units) above what was measured, outside the stated range (below it).
By their numbers in this assay, from the lowest: compound 3; then compounds 2 and 1 (each within the scatter of the next).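

Among these compounds, the position on a double-bonded chain carbon bound to a double-bonded chain carbon is the first place where a single change moves the number beyond the scatter: in this assay, putting 2,4-dichlorophenyl in place of cyclohexyl gives a 5.3-fold lower number from compound 2 to compound 3 (0.72 log units; beyond the scatter) and so stronger inhibition of growth. Among the compounds shown here, the only earlier step, the chloro in place of hydrogen on the aromatic ring of the ketone, gave a 1.1-fold lower number from compound 1 to compound 2 (0.02 log units; within the scatter) and showed no change that could be read, so this position responds in a way the earlier pair gave no sign of. Nothing measured here explains why the number moved at this position.

This single step swaps a non-aromatic ring for an aromatic one and also brings in two chlorines, so the compounds shown cannot say which of these carries the effect; a plain phenyl group at this position would separate the two. They also leave open whether this position would accept something quite different from a ring, such as an amine, a carboxylic acid or a longer chain.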